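Solubility notes: compound 3 to compound 4

A few compounds are considered here, and "the series" means these few. Any claim that something is new, unique, unknown or untested is made for them only; others in the source may bear on it.

Compound 3 `CC(C)C(c1ccc(-c2ccc3cccc(F)c3c2)[nH]c1=O)N1CCNC1=O` stands second highest of the three numbers in a physicochemical assay for solubility, in phosphate buffer, measured as kinetic solubility; a lower number here means a less soluble compound, a higher number a more soluble compound; compound 3 gives 24900 nM. Compound 1 `CC(C)C(c1nnc[nH]1)c1ccc(-c2ccc3cccc(F)c3c2)[nH]c1=O` gives 24500 nM in this assay, and compound 2 `CCn1ncc2c(F)cc(-c3ccc(C(CC)(CC)c4nnc(C)[nH]4)c(=O)[nH]3)cc21` gives 26900 nM in this assay, so the three sit within the scatter of one another. For the measured compounds named here, the only step already measured at the same place, a 1.0-fold higher number from compound 1 to compound 3 (0.01 log units; within the scatter), brought no change beyond the scatter. Compound 4 `CC(C)C(CC(N)=O)c1ccc(-c2ccc3cccc(F)c3c2)[nH]c1=O` differs from compound 3 by carbamoylmethyl in place of 2-oxoimidazolidin-1-yl on a saturated chain carbon bound to an aromatic carbon and a saturated chain carbon. That single measured step is the one that bears on this change, and it was flat, so no step beyond the scatter is expected in this assay in either direction. Compound 4 is expected to give 25000 nM, within a range of 12000 nM to 50000 nM. The step this estimate implies is a 1.0-fold higher number from compound 3 to compound 4 (0.00 log units; within the scatter).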

Compound 4, solubility: 5600 nM
Compound 4: middle estimate off by 4.5-fold (0.65 log units), on the high side; measured number below the stated range.
By their numbers in this assay, from the lowest: compound 4; then compounds 1, 3 and 2 (each within the scatter of the next).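

In this assay the position on the saturated chain carbon is not flat after all: carbamoylmethyl in place of 2-oxoimidazolidin-1-yl gives a 4.4-fold lower number from compound 3 to compound 4 (0.65 log units; beyond the scatter) and carbamoylmethyl in place of 4H-1,2,4-triazol-3-yl gives a 4.4-fold lower number from compound 1 to compound 4 (0.64 log units; beyond the scatter). The two ring groups remain within the scatter of each other, so of the three groups at this place only the open-chain carbamoylmethyl stands apart. No measurement here accounts for this step. As far as these compounds go, whether the lower number follows from the absence of a ring or from the primary amide itself remains open. An amine, a carboxylic acid or a longer chain ending in the same amide at this place could separate the two.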